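Estimating Cytotoxicity of a Carboxymethoxy Benzyl Analogue

The compounds below may be only part of what the source reports. "The series", "measured", "known", "first", "only" and "open" are said of these compounds alone.

Measured in a toxicity assay on MDCK cells (Canis lupus familiaris) for cytotoxicity, read by crystal violet staining, with a stated time of 48 h; a lower number here means that less compound is tolerated, a higher number that more compound is tolerated:
compound 1, `Cc1ccc2[nH]c(=O)c(CN(Cc3ccccc3)Cc3ccc(C(C)(C)C)cc3)cc2c1`: compound 1 gives > 5000 nM, a limit of the assay.
compound 2, `Cc1ccc2[nH]c(=O)c(CN(Cc3ccc(F)cc3)Cc3ccc(C(C)(C)C)cc3)cc2c1`: compound 2 gives > 27000 nM, a limit of the assay.
compound 3, `Cc1ccc2[nH]c(=O)c(CN(Cc3ccc(O)cc3)Cc3ccc(C(C)(C)C)cc3)cc2c1`: compound 3 gives 4900 nM.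

Compound 3 is the only one of the three with a number in this assay; the other two values are limits. The step of an at least 1.0-fold lower number from compound 1 to compound 3 (0.00 log units; that floor lies within the scatter) and the step of an at least 5.5-fold lower number from compound 2 to compound 3 (0.74 log units; beyond the scatter) both end at compound 3, while the step that the two limits leave unreadable from compound 1 to compound 2 cannot be read because one value sits at the limit of > 27000 nM in this assay, at which 1 of the 3 values shown sits, and the other at the limit of > 5000 nM in this assay, at which 1 of the 3 values shown sits.

Compound 4, `Cc1ccc2[nH]c(=O)c(CN(Cc3ccc(OCC(=O)O)cc3)Cc3ccc(C(C)(C)C)cc3)cc2c1`, differs from compound 3 by carboxymethyl in place of hydrogen on an oxygen on an aromatic ring. Among the compounds with values here, none of the measured steps replaces a hydroxy by a carboxymethoxy, so no measured step bears directly on this change. The hydroxy compound 3 gave the lowest number that could be read, and the change to compound 4 keeps the oxygen and extends it. The expected step of a 1.8-fold higher number from compound 3 to compound 4 (0.26 log units; within the scatter) is therefore small, with the number more likely to rise than to fall. Compound 4 is estimated at 9000 nM in this assay, expected between 3000 nM and 30000 nM.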

Compound 4, half-maximal cytotoxic concentration: > 10000 nM
Compound 4 was reported as a limit; the forecaster's own chance of this, stated with the estimate: 45%; middle value at least 1.1-fold (0.04 log units) away from the limit.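

In this assay compound 4 is reported only as a limit: the limit of > 10000 nM in this assay, at which 1 of the 4 values shown sits. At this position, the readable step is an at least 2.0-fold higher number from compound 3 to compound 4 (0.30 log units; that floor lies within the scatter), so placing carboxymethyl on the oxygen on the aromatic ring gave no sign of a number lower than that of the hydroxy compound, although this floor alone does not establish a real rise. The steps from compound 1 and from compound 2 to compound 4 cannot be read, with limits at both ends.

On these data alone, the true size of the change remains open, as does whether it goes with the carboxylic acid or with the ether oxygen alone. A methoxy group in place of the hydroxy, or an amine at the end of the same chain, would bear on that question.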